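A Chloro Substituent Tried on a Second Core

The compounds below may be only part of what the source reports. "The series", "measured", "known", "first", "only" and "open" are said of these compounds alone.

The measured compounds:
compound 1, `CN(C)CCN1CCN(CC(=O)Nc2ccc(-c3nc4cc(Cl)ccc4o3)cc2)CC1`, 4470 nM
compound 2, `CN(C)CCN1CCN(CC(=O)Nc2ccc(-c3nc4ccccc4o3)cc2)CC1`, 5310 nM
compound 3, `Cc1cc(-c2nc3ccccc3o2)ccc1NC(=O)CCl`, 13800 nM

All three were tested in a functional assay on HT-29 cells (Homo sapiens) for cytotoxicity, read by MTT assay, with a stated time of 24 h; a higher number here means a weaker inhibitor, a lower number a stronger inhibitor. Compound 1 and compound 2 share one core; compound 3 has another, and the difference between the two cores is not broken down here. Compound 3 gives the highest number of the three.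

Compound 1 differs from compound 2 by chloro in place of hydrogen on an aromatic carbon, and that change made a step of a 1.2-fold lower number from compound 2 to compound 1 (0.07 log units; within the scatter).

Compound 4, `Cc1cc(-c2nc3cc(Cl)ccc3o2)ccc1NC(=O)CCl`, has not yet been measured in this assay. It differs from compound 3 by chloro in place of hydrogen on an aromatic carbon, the same change as between compound 2 and compound 1.

For compound 4 a step of about a 1.2-fold lower number from compound 3 to compound 4 (0.06 log units; within the scatter) is expected, because the same change gave a 1.2-fold lower number from compound 2 to compound 1 (0.07 log units; within the scatter) on the other core. On that basis the estimate for compound 4 in this assay is 12000 nM, with the range 6000 nM to 25000 nM.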

Compound 4, half-maximal inhibitory concentration: > 100000 nM
Compound 4 ended at the assay's limit; the forecaster's own chance of this, stated with the estimate: 10%; middle value at least 8.3-fold (0.92 log units) from the limit.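

In this assay, chloro in place of hydrogen on an aromatic carbon gave an at least 7.2-fold higher number from compound 3 to compound 4 (0.86 log units; beyond the scatter), and this step does not match the one seen on the other core: the same change on two cores in this assay, a 1.2-fold lower number (0.07 log units; within the scatter) from compound 2 to compound 1 and an at least 7.2-fold higher number (0.86 log units; beyond the scatter) from compound 3 to compound 4, at least 8.6-fold (0.93 log units) apart, beyond the scatter of two such steps

Compound 4 stands at > 100000 nM, which is a limit of the assay and not a number, so the full size of its step stays unknown: the limit of > 100000 nM in this assay, at which 1 of the 4 values shown sits.

The result shows that, for these two pairs, the effect of this change on one core did not predict its effect on the other; it does not show which structural difference between the cores is responsible, and a single pair on each core supports no general rule for the series.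

Going by these compounds, it remains open whether fluoro, bromo or methoxy on that same aromatic carbon would follow the step to compound 1 or the step to compound 4. Also open, on these data alone, is whether a chloro group would give the same result on the core of compound 3 if that core carried the dimethylaminoethyl piperazine chain of compound 1.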